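Ethoxy to methoxy: working notes on compound 4

The source may report more compounds than this note shows. Statements on the series, on what has been measured and on what is new or still open speak of the compounds shown alone.

Three compounds of the series carry numbers in an assay on HeLa cells with Bile acid receptor (Homo sapiens) as the target, read by a luciferase reporter, with a stated time of 24 h; on this read-out higher numbers stand for an effect only at larger amounts of compound and lower numbers for an effect already at smaller amounts. Compound 1 `CC(C)(C)c1ccc(C(=O)NCc2ccc(OC(F)(F)F)cc2)cc1` gives 160 nM, compound 2 `CCOc1ccc(CNC(=O)c2ccc(C(C)(C)C)cc2)cc1` gives 160 nM, and compound 3 `CC(C)(C)c1ccc(C(=O)NCc2ccc(C(=O)O)cc2F)cc1` gives 7.8 nM. Compound 2 stands level with compound 1 at the digits shown, the two together the highest of the three numbers; compound 3 has a markedly lower number, a gap to compound 2 that lies beyond the scatter.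

Within the data shown here, the one step between measured compounds that differ in a single place is no change at the digits printed from compound 1 to compound 2 (within the scatter), ethyl in place of trifluoromethyl on an oxygen on an aromatic ring, and it left the number unchanged within the scatter.

Compound 4 `COc1ccc(CNC(=O)c2ccc(C(C)(C)C)cc2)cc1` differs from compound 2 by hydrogen in place of methyl on a saturated chain carbon bound to an oxygen on an aromatic ring. Cut one bond further out, the change reads ethyl to methyl, ethoxy to methoxy.

Among the measured compounds shown here, only the step from compound 1 to compound 2 bears on this: it altered the group on the same oxygen on the aromatic ring and gave no change. Compound 3 differs from compound 2 elsewhere and does not inform the step. No change beyond the scatter is therefore expected, and the expected step is a 1.1-fold higher number from compound 2 to compound 4 (0.05 log units; within the scatter). Compound 4 is expected to come out at 180 nM, in a range from 70 nM to 450 nM.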

Compound 4, half-maximal effective concentration: 150 nM
Compound 4: the middle estimate sits 1.2-fold (0.08 log units) above what was measured; the range from low to high includes it.
By their numbers in this assay, from the lowest: compound 3; then compounds 4, 1 and 2 (each within the scatter of the next).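

In this assay, the group on the oxygen on the aromatic ring now spans trifluoromethyl, ethyl and methyl, and the new compound adds a second and a third reading of this position: a 1.1-fold lower number from compound 2 to compound 4 (0.03 log units; within the scatter), and a 1.1-fold lower number from compound 1 to compound 4 (0.03 log units; within the scatter). The earlier pair set only trifluoromethyl against ethyl, whereas compounds 1, 2 and 4 together show that, among these three groups, the change from ethoxy to methoxy also leaves the number within the scatter, and none of the three compounds that differ in this one place goes against that reading. No supporting measurement bears on why this position gives so flat a response.

On these data alone, whether the flat response holds for a hydroxyl group on the aromatic ring, or for a longer chain such as butyl on the same oxygen, remains open. Compound 3 differs from these three compounds in more than one place, so the compounds shown also leave open how much of its distance from them belongs to the carboxylic acid and how much to the fluorine.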